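From 4-methoxyphenyl to 3-hydroxyphenyl: compound 3 to compound 4

The source may hold more compounds than are shown below. What is called first, only, known or untested is meant among the compounds shown, and "the series" means these compounds.

Compound 1 `COc1ccc(/C=C2\CCC/C(=C\c3cccc(Br)c3)C2=O)cc1OC`: 4200 nM
Compound 2 `COc1ccccc1/C=C1\CCC/C(=C\c2ccc(OC)c(OC)c2)C1=O`: 7800 nM
Compound 3 `COc1ccc(/C=C2\CCC/C(=C\c3ccc(OC)c(OC)c3)C2=O)cc1`: 6600 nM

All three compounds were tested in a functional assay on SW-620 cells (Homo sapiens) for cytotoxicity, read by MTT assay, with a stated time of 72 h; on this read-out lower numbers stand for stronger inhibition and higher numbers for weaker inhibition. There, compound 3 gives 6600 nM, and its value cannot be told apart from those of the other two. The data show a 1.6-fold higher number from compound 1 to compound 3 (0.20 log units; within the scatter) and a 1.2-fold lower number from compound 2 to compound 3 (0.07 log units; within the scatter).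

The next compound is compound 4 `COc1ccc(/C=C2\CCC/C(=C\c3cccc(O)c3)C2=O)cc1OC`. It carries 3-hydroxyphenyl in place of 4-methoxyphenyl on a double-bonded chain carbon bound to a double-bonded ring carbon.

Among the compounds with values here, three measured steps bear on this change, since each exchanges a group at that same place. Besides the two above, the data show a 1.9-fold higher number from compound 1 to compound 2 (0.27 log units; within the scatter). None of the three goes beyond the scatter in this assay. Within the data shown here, no measured compound carries 3-hydroxyphenyl, so these steps guide the expectation only indirectly, and they give no direction for the new group. No step beyond the scatter is therefore expected, and the estimated change is a 1.3-fold lower number from compound 3 to compound 4 (0.12 log units; within the scatter).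

The estimated value for compound 4 is 5000 nM, with an expected range from 2200 nM to 11000 nM.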

Compound 4, half-maximal inhibitory concentration: 1900 nM
Compound 4: middle estimate off by 2.6-fold (0.42 log units), on the high side; the measured number lies below the stated range.
By their numbers in this assay, from the lowest: compound 4; then compounds 1, 3 and 2 (each within the scatter of the next).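

At the place on a double-bonded chain carbon bound to a double-bonded ring carbon, exchanges among 3-bromophenyl, 2-methoxyphenyl and 4-methoxyphenyl had all stayed within the scatter, but 3-hydroxyphenyl moves the number beyond it in this assay, with modest steps (a 3.5-fold lower number from compound 3 to compound 4 (0.54 log units; beyond the scatter)) and (a 4.1-fold lower number from compound 2 to compound 4 (0.61 log units; beyond the scatter)). The change of hydroxy in place of bromo on an aromatic carbon also goes beyond the scatter (a 2.2-fold lower number from compound 1 to compound 4 (0.34 log units; beyond the scatter)), so compound 4 stands apart from all three earlier compounds and this position proves responsive to the group placed there. No measured evidence accompanies these results that would explain the shift.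

The compounds shown leave open whether the step belongs to the hydroxy group itself or to the 3-substituted pattern it shares with the bromo compound, a question that 3-methoxyphenyl and 4-hydroxyphenyl groups at this place would help to separate. They also leave open how a 3-aminophenyl group would compare with 3-hydroxyphenyl here, and whether a similar step would appear with the other arm of the molecule changed.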